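Removing the tert-butoxycarbonyl group from compound 1

The source may report more compounds than this note shows. Statements on the series, on what has been measured and on what is new or still open speak of the compounds shown alone.

Measured compounds:
compound 1 `CC(C)(C)OC(=O)NCCCCCN1C(Nc2ccc(-c3ccccc3)cc2)=Nc2ccccc2C1CC(=O)NCc1ccccc1`, 88.5%
compound 2 `NCCCCCNC1=Nc2ccccc2C(CC(=O)NCc2ccccc2)N1c1ccc(-c2ccccc2)cc1`, 83.8%
compound 3 `COC(=O)CC1c2ccccc2N=C(NCCCCCNC(=O)OC(C)(C)C)N1c1ccc(-c2ccccc2)cc1`, 86.5%

Three compounds of a shared core were tested in an assay on HEK293 cells for inhibition of Voltage-dependent T-type calcium channel subunit alpha-1G (Homo sapiens), tested at 10 uM; on this read-out lower numbers stand for less inhibition and higher numbers for more inhibition at the one concentration tested (going by the name of the read-out). Compound 1 gives 88.5%, the highest of the three numbers, yet the two others sit close by it: compound 3 gives 86.5% and compound 2 gives 83.8%, and both gaps to compound 1 lie within the scatter of this assay. Nothing in these three values therefore separates one compound from another.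

Compound 4 `NCCCCCN1C(Nc2ccc(-c3ccccc3)cc2)=Nc2ccccc2C1CC(=O)NCc1ccccc1` has not been measured. It differs from compound 1 in one place: hydrogen in place of tert-butoxycarbonyl on an amine nitrogen. Within the data shown here, compound 2 already carries a free amine at the end of its chain and gives 83.8%, a number within the scatter of compound 1, though compound 2 is arranged differently and no direct step between it and compound 1 is known.

For compound 4 the expected change in this assay is small, with a step of a number 3.5 percentage points lower from compound 1 to compound 4 (within the scatter), that is, none beyond the scatter. Compound 4 is estimated at 85%, within the range of 70% to 94%.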

Compound 4, a percentage reported as inhibition, at one concentration (the size of the read-out at that concentration, not a potency): 91.8%
Estimate against measurement, compound 4: 6.8 percentage points below, within the range that was stated.
By their numbers in this assay, from the lowest: compounds 2, 3, 1 and 4 (each within the scatter of the next).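

In this assay, among these compounds, the first step that can be read at this position is the exchange of tert-butoxycarbonyl for hydrogen on an amine nitrogen whose other neighbour is saturated chain carbon, a number 3.3 percentage points higher from compound 1 to compound 4 (within the scatter). The earlier compounds shown here offered no such one-place comparison, and this one shows that the read-out stays within the scatter whether this nitrogen carries tert-butoxycarbonyl, with its 7 heavy atoms, or only hydrogen. Nothing at hand bears on why the change leaves the read-out there.

Among the compounds shown here, whether an acetyl group or a methyl group on this nitrogen, a carboxylic acid in place of the amine, or a longer chain would move the read-out beyond the scatter remains open, since the single step covers only the exchange for hydrogen. The read-out also comes from one concentration and is not a potency, so these numbers cannot tell whether compound 1 and compound 4 differ in potency.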